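Methoxy in place of chloro on an aromatic carbon

The compounds below may be only part of what the source reports. "The series", "measured", "known", "first", "only" and "open" are said of these compounds alone.

In a physicochemical assay for lipophilicity (on this read-out higher numbers stand for higher lipophilicity and lower numbers for lower lipophilicity), compound 3 `C=C(c1ccc2ccccc2c1)C1CCC2(CC1)COC(Nc1ccc(Cl)cc1)OO2` reads 6.15, level with compound 1 `C=C(c1cccc2ccccc12)C1CCC2(CC1)COC(Nc1ccc(Cl)cc1)OO2` at 6.15. Compound 2 `C=C(c1ccc2ccccc2c1)C1CCC2(CC1)COC(Nc1ccccc1)OO2` stands lower, reading 5.59. The next compound to be read is compound 4 `C=C(c1ccc2ccccc2c1)C1CCC2(CC1)COC(Nc1ccc(OC)cc1)OO2`, which carries methoxy in place of chloro on an aromatic carbon, para to a large group (methoxy in place of chloro on an aromatic carbon).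

Among the measured compounds shown here, two measured steps bear on this change. Naphthalen-2-yl in place of naphthalen-1-yl shows no change at the digits printed from compound 1 to compound 3 (within the scatter), but that step lies elsewhere in the molecule and says little here. Chloro in place of hydrogen on an aromatic carbon gives a number 0.56 log units higher from compound 2 to compound 3 (beyond the scatter), and this is the closer precedent. For the measured compounds named here, no methoxy compound has been measured, so the expectation rests on that single modest step. A fall of about the same size is expected, to a number close to compound 2 at 5.59. The expected change is a number 0.50 log units lower from compound 3 to compound 4 (beyond the scatter). Compound 4 is estimated at 5.65, with an expected range of 5.35 to 5.95.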

Compound 4, partition coefficient: 5.46
Estimate against measurement, compound 4: 0.19 log units above, within the range that was stated.
By their numbers in this assay, from the lowest: compounds 4 and 2 (each within the scatter of the next); then compounds 1 and 3 (each within the scatter of the next).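

In this assay, methoxy in place of chloro gives a number 0.69 log units lower from compound 3 to compound 4 (beyond the scatter) on the aromatic carbon para to a large group, so these two groups are not interchangeable at this position. Methoxy in place of hydrogen gives a number 0.13 log units lower from compound 2 to compound 4 (within the scatter) at the same carbon, so this read-out does not separate methoxy from hydrogen here, and among the three groups read at this carbon, only chloro stands apart. No measurement on hand accounts for the separation of chloro from the other two groups.

Still open, from the compounds shown here alone, is how other groups at this carbon would read, such as fluoro, trifluoromethyl, nitrile or an amine. Also open, going by these compounds, is whether methoxy would read the same way with naphthalen-1-yl in place of naphthalen-2-yl on the chain.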